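This account rests on a few compounds, and the source may have more. Where it says the series, first, only, none or still open, it means among the compounds named here.

Of the compounds shown here, three sharing one core have been tested in a functional assay on MCF7 cells (Homo sapiens) for inhibition, read by sulforhodamine B assay, with a stated time of 72 h; on this read-out lower numbers stand for stronger inhibition and higher numbers for weaker inhibition. Compound 1 `COc1ccc2cc(C(C)c3nnc4n3N=C(c3ccc(OC(F)(F)F)cc3)CS4)ccc2c1` gives 8800 nM in this assay. Compound 2 `CC(c1ccc(-c2ccccc2)c(F)c1)c1nnc2n1N=C(c1ccc(Cl)cc1Cl)CS2` gives 7600 nM. Compound 3 `CC(c1ccc(-c2ccccc2)c(F)c1)c1nnc2n1N=C(c1ccccc1)CS2` gives 7400 nM. Compound 3 carries the lowest number of the three, yet its distance to compound 2 and to compound 1 lies within the usual scatter, so no ranking among them can be read. For the measured compounds named here, the single measured step between close neighbours, a 1.0-fold lower number from compound 2 to compound 3 (0.01 log units; within the scatter), shows that exchanging the aryl group on the carbon with a double bond to nitrogen barely moves the read-out.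

The next compound, compound 4 `COc1ccc(C2=Nn3c(nnc3C(C)c3ccc(-c4ccccc4)c(F)c3)SC2)cc1`, differs from compound 3 by methoxy in place of hydrogen on an aromatic carbon, that is, a methoxy in place of hydrogen on an aromatic carbon, para to a large group; seen one bond further out, phenyl becomes 4-methoxyphenyl. The measured step that bears on it is a 1.0-fold lower number from compound 2 to compound 3 (0.01 log units; within the scatter), a larger exchange at the same aryl group that stayed within the scatter. Compound 1, which differs in more than one place, also shows a number within the scatter of compound 3. Because of a 1.0-fold lower number from compound 2 to compound 3 (0.01 log units; within the scatter), no step beyond the scatter is expected for a 1.0-fold higher number from compound 3 to compound 4 (0.01 log units; within the scatter). Compound 4 is therefore estimated at 7500 nM, with a likely range from 3500 nM to 16000 nM.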

Compound 4, half-maximal inhibitory concentration: 2600 nM
For compound 4 the middle estimate is 2.9-fold (0.46 log units) above the measured one, outside the stated range (below it).
By their numbers in this assay, from the lowest: compound 4; then compounds 3, 2 and 1 (each within the scatter of the next).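

In this assay, for the compounds shown here, the aryl group on the carbon with a double bond to nitrogen proves able to move the read-out: a methoxy in place of hydrogen, on an aromatic carbon para to a large group, gives a 2.8-fold lower number from compound 3 to compound 4 (0.45 log units; beyond the scatter), the first step in this small set that clears the scatter. The exchange of 2,4-dichlorophenyl for 4-methoxyphenyl gives a similar result, a 2.9-fold lower number from compound 2 to compound 4 (0.47 log units; beyond the scatter), while the exchange of 2,4-dichlorophenyl for phenyl gave a 1.0-fold lower number from compound 2 to compound 3 (0.01 log units; within the scatter), so this position responds to some groups and not to others. Nothing measured here offers a reason for the step made by the methoxy group.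

The compounds shown leave open whether a hydroxy, ethoxy or dimethylamino group on the same aromatic carbon would give a number like that of compound 4, or whether methoxy is special among them. They also leave open whether methoxy in place of hydrogen at this spot would give a step of similar size if the rest of the molecule were that of compound 1.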